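A few compounds are considered here, and "the series" means these few. Any claim that something is new, unique, unknown or untested is made for them only; others in the source may bear on it.

Measured so far:
compound 1, `Cc1ccc2nc(C(=O)Nc3c(F)cc(-c4cccc(F)c4)cc3F)c(C)c(C(=O)O)c2c1`, 31.3%
compound 2, `CCc1ccc2nc(C(=O)Nc3c(F)cc(-c4cccc(F)c4)cc3F)c(C)c(C(=O)O)c2c1`, 15.2%
compound 3, `CCOc1ccc2nc(C(=O)Nc3c(F)cc(-c4cccc(F)c4)cc3F)c(C)c(C(=O)O)c2c1`, 26.5%

These three share one core and differ only in the group on the outer ring. In a functional assay on Hep 3B2 cells (Homo sapiens) for antiproliferative activity, read by MTT assay, with a stated time of 24 h, tested at 3.7 ug/mL (a lower number here means a weaker effect, a higher number a stronger effect of the compound at the concentration tested), compound 2 gives the lowest of the three numbers. The change hydrogen in place of methyl on a saturated chain carbon bound to an aromatic carbon gives a step of a number 16.1 percentage points higher from compound 2 to compound 1 (beyond the scatter). Compound 3 carries a different core from compound 2, set apart by ethoxy in place of ethyl on an aromatic carbon; the step of a number 11.3 percentage points higher from compound 2 to compound 3 (beyond the scatter) follows it, while a number 4.8 percentage points lower from compound 1 to compound 3 (within the scatter) separates compound 1 from compound 3.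

Compound 4, `COc1ccc2nc(C(=O)Nc3c(F)cc(-c4cccc(F)c4)cc3F)c(C)c(C(=O)O)c2c1`, is not yet measured. It differs from compound 3 by hydrogen in place of methyl on a saturated chain carbon bound to an oxygen on an aromatic ring. For the measured compounds named here, this is the same kind of change as the one from compound 2 to compound 1, though not the same: there the place was on a saturated chain carbon bound to an aromatic carbon, here it is on a saturated chain carbon bound to an oxygen on an aromatic ring. Resting on the earlier step of a number 16.1 percentage points higher from compound 2 to compound 1 (beyond the scatter), a rise of similar or somewhat smaller size is expected for compound 4, estimated as a number 8.5 percentage points higher from compound 3 to compound 4 (within the scatter) in this assay. Compound 4 is thus estimated at 35%, between 18% and 52%.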

Compound 4, a percentage reported as inhibition, at one concentration (the size of the read-out at that concentration, not a potency): 1.62%
Estimate against measurement, compound 4: 33.4 percentage points above; measured number below the stated range.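

Taking a methyl off the end of the outer group does not carry over from one core to the other in this assay, and the new result, a number 24.9 percentage points lower from compound 3 to compound 4 (beyond the scatter), runs opposite to the earlier step: the same change on two cores in this assay, a number 16.1 percentage points higher (beyond the scatter) from compound 2 to compound 1 and a number 24.9 percentage points lower (beyond the scatter) from compound 3 to compound 4, 41 percentage points apart, beyond the scatter of two such steps

Methoxy also reads low against the plain chains, with a number 13.6 percentage points lower from compound 2 to compound 4 (beyond the scatter) and a number 29.7 percentage points lower from compound 1 to compound 4 (beyond the scatter), so compound 4 has the lowest number of the four. This shows that a step seen on the ethyl compound cannot be assumed for the ethoxy compound, but it rests on a single pair for each core at one concentration, so it gives neither a reason for the reversal nor a rule for other cores.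

Open, going by these compounds, is how a longer chain such as propoxy, or an amine or a chlorine atom, would read on the outer ring. Also open, on these data alone, is whether the low number of compound 4 belongs to methoxy alone or would recur with a related group such as hydroxy.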